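Replacing 1-Phenylethyl by 1-(Pyrimidin-5-yl)ethyl on the Sulfur

The source may report more compounds than this note shows. Statements on the series, on what has been measured and on what is new or still open speak of the compounds shown alone.

Compound 1 `CC(Sc1nc2nn(CC3COC3)cc2c(=O)n1-c1ccccc1)c1ccccc1`: in an assay on isolated protein for inhibition of aldehyde dehydrogenase 1A1 (Homo sapiens) (on this read-out lower numbers stand for stronger inhibition and higher numbers for weaker inhibition), compound 1 gives 100 nM.
Compound 2 `C[C@@H](Sc1nc2c(cnn2C)c(=O)n1-c1ccccc1)c1ccccc1`: in this assay compound 2 gives 70 nM.
Compound 3 `Cn1ncc2c(=O)n(-c3ccccc3)c(/C=C/c3cccc(F)c3)nc21`: in this assay compound 3 gives 270 nM.

Compound 2 has the lowest of the three numbers. The number of compound 1 lies within the usual scatter of it, so the two cannot be told apart; compound 3 lies beyond the scatter, with a clearly higher number.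

Compound 4 `CC(Sc1nc2c(cnn2C)c(=O)n1-c1ccccc1)c1cncnc1` has not yet been measured. It differs from compound 2 in one place: 1-(pyrimidin-5-yl)ethyl in place of 1-phenylethyl on a sulfur. Among the compounds with values here, no measured pair shows this change, so its size is open.

Compound 4 is expected to show a number close to that of compound 2, with a modest rise in this assay that may stay inside the scatter. Compound 4 is therefore estimated at 150 nM, with a range from 50 nM to 500 nM. This amounts to an expected step of a 2.1-fold higher number from compound 2 to compound 4 (0.33 log units; beyond the scatter).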

Compound 4, half-maximal inhibitory concentration: 94 nM
For compound 4 the middle estimate is 1.6-fold (0.20 log units) above the measured one; the range from low to high includes it.
By their numbers in this assay, from the lowest: compounds 2, 4 and 1 (each within the scatter of the next); then compound 3.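

Replacing 1-phenylethyl by 1-(pyrimidin-5-yl)ethyl on the sulfur gives, in this assay, a 1.3-fold higher number from compound 2 to compound 4 (0.13 log units; within the scatter), so compound 2 and compound 4 cannot be told apart. Within the data shown here, this is the first change seen at this position alone, and it shows that a ring of carbon only can give way to a ring with two hetero atoms, and so two hydrogen-bond acceptors, with no difference this read-out can detect. Nothing at hand explains this result.

As far as these compounds go, compound 2 has a defined stereocentre and compound 4 does not, so the importance of the spatial arrangement at that centre remains open. Also open, from the compounds shown here alone, is how 1-(pyridin-3-yl)ethyl, or a ring carrying an amine or a carboxylic acid, would behave on the sulfur.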